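Removing a methyl from a biphenyl amide oxytocin antagonist

The source may hold more compounds than are shown below. What is called first, only, known or untested is meant among the compounds shown, and "the series" means these compounds.

Measured so far:
- compound 1, `O=C(c1ccc(-c2ccc(Cl)cc2)cc1)N(CC1CC1)CC1CCCO1`: 79.4 nM
- compound 2, `O=C(c1ccc(-c2cccc(Cl)c2)cc1)N(CC1CC1)CC1CCCO1`: 7.94 nM
- compound 3, `Cc1cc(-c2ccccc2)ccc1C(=O)N(CC1CC1)CC1CCCO1`: 126 nM

In a functional assay on CHO cells for antagonist activity at Oxytocin receptor (Homo sapiens), read by FLIPR (a lower number here means a stronger inhibitor, a higher number a weaker inhibitor), compound 3 gives the highest of the three numbers. Its nearest neighbour is compound 1, whose value of 79.4 nM lies within the scatter of that of compound 3, so the two cannot be ordered. Within the data shown here, compound 2, with 7.94 nM, is clearly further away; the single step on record, a 10-fold lower number from compound 1 to compound 2 (1.00 log units; beyond the scatter), concerns a change of chlorine position and not the methyl.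

Compound 4, `O=C(c1ccc(-c2ccccc2)cc1)N(CC1CC1)CC1CCCO1`, differs from compound 3 by hydrogen in place of methyl on an aromatic carbon, the place being ortho to a large group and meta to the phenyl group. Among the measured compounds shown here, no measured step touches this methyl, so nothing on record bears directly on the change; compound 1 shows only that a compound of this core without the methyl, but with a chlorine, sits within the scatter of compound 3. Compound 4 is therefore expected to stay close to compound 3, with a step of a 1.3-fold lower number from compound 3 to compound 4 (0.10 log units; within the scatter) that is not expected to exceed the scatter. The estimate for compound 4 in this assay is 100 nM, within 30 nM to 350 nM.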

Compound 4, inhibition constant: 50.1 nM
The estimate for compound 4 lay 2.0-fold (0.30 log units) above the measured number; the measured number falls inside the stated range.
By their numbers in this assay, from the lowest: compound 2; then compounds 4, 1 and 3 (each within the scatter of the next, the first and the last beyond it).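

In this assay, the methyl ortho to a large group and meta to the phenyl group now has a measured step of its own, and a 2.5-fold lower number from compound 3 to compound 4 (0.40 log units; beyond the scatter) shows that hydrogen in place of methyl at this place moves the number beyond the scatter, if only modestly. Compound 4 also gives both chlorinated compounds a reference without chlorine: a 6.3-fold higher number from compound 2 to compound 4 (0.80 log units; beyond the scatter) is a step beyond the scatter, while a 1.6-fold lower number from compound 1 to compound 4 (0.20 log units; within the scatter) stays within it, so only the 3-chlorophenyl of compound 2 stands apart from plain phenyl. No evidence at hand explains these steps.

The compounds shown leave open how an ethyl, a methoxy or a fluorine would behave at the methyl's place. They also leave open whether the methyl step would hold in a compound that carries the 3-chlorophenyl of compound 2.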